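Anilino replaces an aryl group on a weak compound

The source may report more compounds than this note shows. Statements on the series, on what has been measured and on what is new or still open speak of the compounds shown alone.

In a functional assay on A549 cells (Homo sapiens) for antiproliferative activity, read by MTT assay, with a stated time of 72 h (on this read-out lower numbers stand for stronger inhibition and higher numbers for weaker inhibition), compound 1 `COc1cc(C(=O)c2sc3ccccc3c2-c2ccc(Cl)cc2)cc(OC)c1OC` gives 7500 nM. Compound 2 `COc1ccc(-c2c(C(=O)c3cc(OC)c(OC)c(OC)c3)sc3ccccc23)cc1C` stands at > 10000 nM, which is a limit and not a number. Compound 3 `COc1cc(C(=O)c2sc3ccccc3c2Nc2ccccc2)cc(OC)c1OC` differs from compound 2 on an aromatic carbon, with anilino in place of 4-methoxy-3-methylphenyl on an aromatic carbon. Among the measured compounds shown here, the only measured step that bears on this, an at least 1.3-fold higher number from compound 1 to compound 2 (0.12 log units; that floor lies within the scatter), changed the group on that same carbon. It sets only a floor, so it gives weak guidance on size. A modest move towards stronger inhibition is expected, an at least 2.0-fold lower number from compound 2 to compound 3 (0.30 log units; that floor lies within the scatter). For compound 3 the estimate in this assay is 5000 nM, with an expected range of 800 nM to 10000 nM.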

Compound 3, half-maximal inhibitory concentration: 3000 nM
The estimate for compound 3 lay 1.7-fold (0.22 log units) above the measured number; low and high end bracket the measured number.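

Anilino on this carbon gives a 2.5-fold lower number from compound 1 to compound 3 (0.40 log units; beyond the scatter), so this position can respond by more than the scatter, which the swap between the two aryl groups did not show. Replacing the other aryl group with anilino gives an at least 3.3-fold lower number from compound 2 to compound 3 (0.52 log units; beyond the scatter). That size is only a floor, set by a limit rather than a number: the limit of > 10000 nM in this assay, at which 1 of the 3 values shown sits.

From the compounds shown here alone, whether the gain comes from the nitrogen link or from the ring it carries stays open. So does how a plain amine, a benzylamino group or a 4-chloroanilino group would behave on this carbon.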